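Side group of compound 3 in exchange

The source may hold more compounds than are shown below. What is called first, only, known or untested is meant among the compounds shown, and "the series" means these compounds.

Compound 1 `CC(C)=CCC[C@]1(C)/C=C/[C@@H](OC(=O)C=C(C)C)[C@](C)(O)/C=C/C(=O)/C(C(=O)O)=C\C1`: > 10000 nM, a limit of the assay
Compound 2 `CC(C)=CCC[C@]1(C)/C=C/[C@@H](OC(=O)C=C(C)C)[C@](C)(O)/C=C/C(=O)/C(CN(C)C)=C\C1`: 590 nM
Compound 3 `CC(C)=CCC[C@]1(C)/C=C/[C@@H](OC(=O)C=C(C)C)[C@](C)(O)/C=C/C(=O)/C(CN2CCN(C)CC2)=C\C1`: 940 nM

All values come from a functional assay on A549 cells (Homo sapiens) for antiproliferative activity, read by MTT assay, with a stated time of 48 h; on this read-out higher numbers stand for weaker inhibition and lower numbers for stronger inhibition. Compound 3, at 940 nM, stands within the scatter of compound 2, at 590 nM. Compound 1 is the only one recorded at a limit.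

Compound 4 `CSC(=S)OC/C1=C/C[C@](C)(CCC=C(C)C)/C=C/[C@@H](OC(=O)C=C(C)C)[C@](C)(O)/C=C/C1=O` is not yet measured. Its change is a group of 5 heavy atoms (2 carbon, 1 oxygen, 2 sulfur; no ring) in place of a group of 7 heavy atoms (5 carbon, 2 nitrogen; one six-membered non-aromatic ring with 2 hetero atoms), on a saturated chain carbon bound to a double-bonded ring carbon. The closest guide is a 1.6-fold higher number from compound 2 to compound 3 (0.20 log units; within the scatter), an exchange of one group for another at this same place, and it stayed within the scatter. The large steps, an at least 16-fold lower number from compound 1 to compound 2 (1.22 log units; beyond the scatter) and an at least 10-fold lower number from compound 1 to compound 3 (1.02 log units; beyond the scatter), were made on the double-bonded ring carbon itself, so they bear less directly, though they show that the series can move far. Among the compounds with values here, no measured compound carries the entering group, so the range stays wide. Within the data shown here, no step clearly beyond the scatter is expected in this assay, with the greater risk towards higher numbers. The expected change is a 1.5-fold higher number from compound 3 to compound 4 (0.17 log units; within the scatter). For compound 4 the estimate is 1400 nM, with an expected range of 300 nM to 6000 nM.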

Compound 4, half-maximal inhibitory concentration: 380 nM
The estimate for compound 4 lay 3.7-fold (0.57 log units) above the measured number; the range from low to high includes it.
By their numbers in this assay, from the lowest: compounds 4, 2 and 3 (each within the scatter of the next, the first and the last beyond it). At a limit, above all of these: compound 1.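

In this assay, within the data shown here, this place, on a saturated chain carbon bound to a double-bonded ring carbon, does not depend on an amine: the group with oxygen and two sulfur atoms gives a 2.5-fold lower number from compound 3 to compound 4 (0.39 log units; beyond the scatter), the first exchange here to pass the scatter, though only modestly. Against the smaller dimethylamino group the same entering group gives a 1.6-fold lower number from compound 2 to compound 4 (0.19 log units; within the scatter), so compound 4 and compound 2 cannot be ordered. Set against the carboxy group, the result reads an at least 26-fold lower number from compound 1 to compound 4 (1.42 log units; beyond the scatter), a step taken from a limit of the assay: the limit of > 10000 nM in this assay, at which 1 of the 4 values shown sits.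

Going by these compounds, whether the sulfur atoms matter stays open, as an acetate ester or a free hydroxyl on the same chain carbon would be needed to tell. Also open, on these data alone, is how a morpholine or a primary amine would read at this place.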